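Sulfonamide series: methoxy for chloro on compound 1

The compounds below may be only part of what the source reports. "The series", "measured", "known", "first", "only" and "open" are said of these compounds alone.

The series shares the core of compound 1 `O=S(=O)(Nc1ccc(-c2nc3ccccc3o2)cc1)c1ccccc1Cl`. In an assay on cells for inhibition of HSP60/HSP10 (Homo sapiens), with a stated time of 60 min (on this read-out lower numbers stand for stronger inhibition and higher numbers for weaker inhibition), compound 1 gives > 100000 nM, which is a limit of the assay rather than a number. Compound 2 `O=S(=O)(Nc1ccc2oc(-c3ccccc3)nc2c1)c1cccc(F)c1` gives > 100000 nM in this assay, again a limit. Compound 3 `O=S(=O)(Nc1ccc2oc(-c3ccccc3)nc2c1)c1ccc(Cl)cc1` gives > 100000 nM in this assay, also a limit. Within the data shown here, the one measured step, a step that the two limits leave unreadable from compound 2 to compound 3, is unreadable because all three values sit at the limit of > 100000 nM in this assay, at which 3 of the 3 values shown sit. Compound 1 thus stands at that same limit, and no number places it among the others.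

Compound 4 `COc1ccccc1S(=O)(=O)Nc1ccc(-c2nc3ccccc3o2)cc1` differs from compound 1 by methoxy in place of chloro on an aromatic carbon. Among the measured compounds shown here, no measured step carries this change, and the single step that exists gives no size to lean on. Resting on the limit of > 100000 nM in this assay, at which 3 of the 3 values shown sit, for compound 1, compound 4 is expected to give 100000 nM in this assay, within 30000 nM to 300000 nM. The expected step of a number no higher from compound 1 to compound 4 (the limit leaves the size open) is none beyond the scatter, most likely another limit.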

Compound 4, half-maximal inhibitory concentration: > 100000 nM
Compound 4 was reported as a limit (the forecaster's own chance of this, stated with the estimate: 85%); the middle value lies on the limit itself.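

No step can be read from compound 1 to compound 4, because both values are limits and not numbers: the limit of > 100000 nM in this assay, at which 4 of the 4 values shown sit.

The compounds shown leave open whether any change to the series gives a number rather than a limit in this assay.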